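The compounds below may be only part of what the source reports. "The series", "measured", "known", "first", "only" and "open" are said of these compounds alone.

Compound 1 `CCC(=O)NC(c1ccco1)c1cc(Cl)c2cccnc2c1O` gives 1000 nM.
Compound 2 `CC(=O)NC(c1ccco1)c1cc(Cl)c2cccnc2c1O` gives 3000 nM.
Compound 3 `O=C(NC(c1ccco1)c1cc(Cl)c2cccnc2c1O)c1ccccc1` gives > 25000 nM.

In an assay for inhibition of Polyunsaturated fatty acid lipoxygenase ALOX12 (Homo sapiens), read by spectrophotometry (a lower number here means a stronger inhibitor, a higher number a weaker inhibitor), compound 3 gives no number but a limit, > 25000 nM. Compound 4 `Cc1ccc(C(=O)NC(c2ccco2)c2cc(Cl)c3cccnc3c2O)cc1` differs from compound 3 in one place: methyl in place of hydrogen on an aromatic carbon. Within the data shown here, the steps that bear on this change are the ones that put the phenyl onto the carbonyl carbon: an at least 25-fold higher number from compound 1 to compound 3 (1.39 log units; beyond the scatter) and an at least 8.3-fold higher number from compound 2 to compound 3 (0.92 log units; beyond the scatter), both ending at the limit of > 25000 nM in this assay, at which 1 of the 3 values shown sits. Among the measured compounds shown here, a methyl added to that phenyl makes the group on the carbonyl carbon larger still, and none of the measured compounds shows a gain on enlarging it. Compound 4 is therefore expected to stay at the limit, with the expected step being a step that the limit leaves unreadable from compound 3 to compound 4. The estimate for compound 4 is 40000 nM, with a range from 15000 nM to 120000 nM.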

Compound 4, half-maximal inhibitory concentration: > 25000 nM
Compound 4: only a limit was reported; the forecaster's own chance of this, stated with the estimate: 80%; the middle value does not contradict the limit.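

In this assay compound 4 gives > 25000 nM, which is a limit and not a number. A methyl on the aromatic carbon of the phenyl therefore does not bring the compound back into the readable range, and the step between the two limits cannot be read. The gap to the short acyl chains holds, with an at least 8.3-fold higher number from compound 2 to compound 4 (0.92 log units; beyond the scatter) and an at least 25-fold higher number from compound 1 to compound 4 (1.39 log units; beyond the scatter), and the limit now covers more of the set: the limit of > 25000 nM in this assay, at which 2 of the 4 values shown sit.

On these data alone, whether an amine or a carboxylic acid on this ring would give a readable value stays open. So does whether a longer chain in place of the ethyl of compound 1 would give a lower number.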